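Cyclopentyl Amide Variant: Expected Mouse Microsomal Clearance

The source may hold more compounds than are shown below. What is called first, only, known or untested is meant among the compounds shown, and "the series" means these compounds.

Within the data shown here, in an in vitro ADME assay on microsomes from liver (Mus musculus) for pharmacokinetics, read by LC-MS, with a stated time of 10 min, tested at 1 uM (on this read-out lower numbers stand for slow clearance and higher numbers for fast clearance), compound 2 `CN1C[C@H](C(=O)Nc2cccc(F)c2)[C@@H](c2ccc(/C=C/C(=O)Nc3ccccc3N)cc2)C1` gives 56 mL/min/kg, one of only two numbers in hand. Compound 1 `CN1C[C@H](C(=O)Nc2ccc(C3CC3)cc2)[C@@H](c2ccc(/C=C/C(=O)Nc3ccccc3N)cc2)C1` gives 60 mL/min/kg in this assay, and a 1.1-fold lower number from compound 1 to compound 2 (0.03 log units; within the scatter), so the two stand together. Compound 3 `CN1C[C@H](C(=O)NC2CCCC2)[C@@H](c2ccc(/C=C/C(=O)Nc3ccccc3N)cc2)C1` differs from compound 2 by cyclopentyl in place of 3-fluorophenyl on an amide-type nitrogen. Among the measured compounds shown here, the one measured step exchanges one aryl amide substituent for another and lay within the scatter; no step in hand covers an aromatic-to-non-aromatic exchange. The expectation is therefore no step beyond the scatter, no change at the digits printed from compound 2 to compound 3 (within the scatter). Compound 3 is estimated at 56 mL/min/kg, with a range from 28 mL/min/kg to 112 mL/min/kg.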

Compound 3, clearance: 61 mL/min/kg
Compound 3: middle estimate off by 1.1-fold (0.04 log units), on the low side; measured number inside the range.
By their numbers in this assay, from the lowest: compounds 2, 1 and 3 (each within the scatter of the next).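

In this assay, exchanging the aromatic 3-fluorophenyl for the non-aromatic cyclopentyl on the amide-type nitrogen gives a 1.1-fold higher number from compound 2 to compound 3 (0.04 log units; within the scatter), and exchanging 4-cyclopropylphenyl for cyclopentyl gives a 1.0-fold higher number from compound 1 to compound 3 (0.01 log units; within the scatter). Across these three compounds, a carbon ring of either kind at this position leaves clearance within the scatter. No evidence here explains this result. On these data alone, what an amine, a carboxylic acid or a longer carbon chain on this nitrogen would give remains open, as does whether any change elsewhere on the shared core would move the number.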